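A few compounds are considered here, and "the series" means these few. Any claim that something is new, unique, unknown or untested is made for them only; others in the source may bear on it.

Of the compounds shown here, two with a shared core have been measured in an assay on cell membranes for binding affinity to adenosine receptor A1 (Bos taurus), read by radioligand binding; a lower number here means a stronger inhibitor, a higher number a weaker inhibitor. Compound 1 `Cc1cccc(Nc2ncnc3c2nnn3Cc2ccccc2)c1` gives 1100 nM. For the measured compounds named here, compound 2 `Clc1cccc(Nc2ncnc3c2nnn3Cc2ccccc2)c1` gives 463 nM, and the single measured step, a 2.4-fold lower number from compound 1 to compound 2 (0.38 log units; beyond the scatter), is a chloro in place of a methyl on an aromatic carbon. Going by the values given here, on the numbers so far compound 2 stands lowest of the two, with compound 1 as its only neighbour.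

Compound 3 `CC(Nc1ncnc2c1nnn2Cc1ccccc1)c1ccccc1` changes a different part of the molecule: 1-phenylethyl in place of 3-chlorophenyl on a nitrogen on an aromatic ring. Among the compounds with values here, the one measured step concerns only a substituent on the aryl ring, so it does not bear on exchanging the whole aryl group for a 1-phenylethyl group. Within the data shown here, no measured pair speaks to this change, and the expectation rests on the change itself. A modest step towards a higher number, a 2.6-fold higher number from compound 2 to compound 3 (0.41 log units; beyond the scatter), is expected. Compound 3 is expected to give about 1200 nM in this assay, with a range from 250 nM to 6000 nM.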

Compound 3, inhibition constant: 438 nM
Compound 3: the middle estimate sits 2.7-fold (0.44 log units) above what was measured, within the range that was stated.
By their numbers in this assay, from the lowest: compounds 3 and 2 (each within the scatter of the next); then compound 1.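

In this assay the group on this nitrogen can change from an aryl ring to 1-phenylethyl without losing affinity: 1-phenylethyl in place of 3-chlorophenyl gives a 1.1-fold lower number from compound 2 to compound 3 (0.02 log units; within the scatter) and so no real change. Set against the methyl-bearing ring, the same group gives a 2.5-fold lower number from compound 1 to compound 3 (0.40 log units; beyond the scatter) so it matches the chloro compound, not the methyl one, even though it carries no chlorine. Nothing available explains why these two different groups give such similar numbers.

Open, going by these compounds, is whether a benzyl group, a longer chain such as 2-phenylethyl or a cyclohexyl ring on this nitrogen would hold the number at this level. Also open, on these data alone, is whether a chloro on the ring of 1-phenylethyl would shift the number as chloro in place of methyl did on the aryl ring.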